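The source may hold more compounds than are shown below. What is called first, only, known or untested is meant among the compounds shown, and "the series" means these compounds.

Working notes on the series.

The shared core of compound 1 `O=c1ccn(COCCO)c(=O)[nH]1` carries a (2-hydroxyethoxy)methyl group on a ring nitrogen. In a functional assay on L1210 cells (Mus musculus) for inhibition (on this read-out lower numbers stand for stronger inhibition and higher numbers for weaker inhibition), compound 1 gives > 1000 ug/mL, which is a limit of the assay rather than a number. Going by the values given here, compound 2 `Nc1nc(=O)n(COCCO)cc1[N+](=O)[O-]` is the only other compound with a value; in this assay compound 2 gives 71 ug/mL. Where compound 1 stands can be said only as far as the limit goes: the limit of > 1000 ug/mL in this assay, at which 1 of the 2 values shown sits. Among the compounds with values here, no single-change pair between the two measured compounds exists, so no measured step sets a scale.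

Compound 3 `O=c1[nH]c(=O)n(COCCO)cc1/C=C/Br` is the one still to be measured. It differs from compound 1 by 2-bromoethenyl in place of hydrogen on an aromatic carbon. Within the data shown here, with no measured step to lean on, the size of the step from compound 1 to compound 3 is an open guess, and a value that again runs into the limit cannot be ruled out. On balance compound 3 is expected to move toward stronger inhibition, with an at least 2.5-fold lower number from compound 1 to compound 3 (0.39 log units; beyond the scatter) as the estimated step. In this assay compound 3 is estimated at 400 ug/mL, within a range from 100 ug/mL to 1000 ug/mL.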

Compound 3, concentration for 50% inhibition: > 1000 ug/mL
Compound 3: no number, only a limit; the forecaster's own chance of this, stated with the estimate: 45%; at least 2.5-fold (0.39 log units) between middle value and limit.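

Going by these compounds alone, compound 1 and compound 3 both give only a limit in this assay, so no step between them can be read; both stand at the same point: the limit of > 1000 ug/mL in this assay, at which 2 of the 3 values shown sit. The compounds shown leave open whether 2-bromoethenyl in place of hydrogen on an aromatic carbon changes inhibition in this assay at all, and by how much.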